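Methoxy for fluoro on two related cores

This account rests on a few compounds, and the source may have more. Where it says the series, first, only, none or still open, it means among the compounds named here.

Compound 1 `COC(=O)[C@@]1(C)CCC=C2[C@@H]1CC[C@@H](C)[C@]2(C)Cc1c(C)[nH]c2ccc(F)cc12` and compound 2 `COC(=O)[C@@]1(C)CCC=C2[C@@H]1CC[C@@H](C)[C@]2(C)Cc1c(C)[nH]c2ccc(OC)cc12` share one core; compound 3 `COC(=O)[C@@]1(C)CC[C@@H]2C3=C1CC[C@@H](C)[C@]3(C)C[C@@H]1c3cc(F)ccc3N[C@H]21` and compound 4 `COC(=O)[C@@]1(C)CC[C@@H]2C3=C1CC[C@@H](C)[C@]3(C)C[C@@H]1c3cc(OC)ccc3N[C@H]21` share another. The difference between the two cores is not broken down here.

In a functional assay on T47D cells (Homo sapiens) for inhibition, read by sulforhodamine B assay, with a stated time of 48 h (a lower number here means a stronger inhibitor of growth, a higher number a weaker inhibitor of growth), compound 1 gives 15000 nM, compound 2 gives 15000 nM and compound 3 gives 27000 nM; the values of compound 1 and compound 3 lie within the scatter of each other.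

The measured step is no change at the digits printed from compound 1 to compound 2 (within the scatter), for the change (methoxy in place of fluoro on an aromatic carbon). The change to compound 4 is the same kind: methoxy in place of fluoro on an aromatic carbon. The places differ in that the ring belongs to a fused or bridged system of two rings in compound 1 but of five rings in compound 3.

For compound 4 the expected step is no change at the digits printed from compound 3 to compound 4 (within the scatter), resting on the step of no change at the digits printed from compound 1 to compound 2 (within the scatter). Compound 4 is thus estimated at 27000 nM, between 12000 nM and 60000 nM.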

Compound 4, concentration for 50% growth inhibition: 19000 nM
Estimate against measurement, compound 4: 1.4-fold (0.15 log units) above; low and high end bracket the measured number.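

In this assay, methoxy in place of fluoro gives a 1.4-fold lower number from compound 3 to compound 4 (0.15 log units; within the scatter). The change reads the same on the two cores: the same change on two cores in this assay, no change at the digits printed (within the scatter) from compound 1 to compound 2 and a 1.4-fold lower number (0.15 log units; within the scatter) from compound 3 to compound 4, 1.4-fold (0.15 log units) apart, within the scatter of two such steps

This shows that the change carries across these two cores without a step beyond the scatter, but it rests on a single pair per core in one cell line. Since neither step leaves the scatter, it does not show that the two cores would also respond alike to a change with a real effect.

Open, on these data alone, is whether another group on this aromatic carbon, such as an amine, a carboxylic acid or a longer alkoxy chain, would shift growth inhibition beyond the scatter on either core.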